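A few compounds are considered here, and "the series" means these few. Any claim that something is new, unique, unknown or untested is made for them only; others in the source may bear on it.

Measured compounds in an ADME assay on Vero cells (Chlorocebus sabaeus) for cytotoxicity, with a stated time of 4 days; on this read-out lower numbers stand for stronger inhibition and higher numbers for weaker inhibition:
compound 1, `Cc1ccc(OCc2cn(-c3ccc(S(=O)(=O)N4CCc5ccccc5C4)cc3)nn2)cc1`, gives > 50 ug/mL, a limit of the assay.
compound 2, `O=Cc1ccc(OCc2cn(-c3ccc(S(=O)(=O)N4CCc5ccccc5C4)cc3)nn2)cc1`, gives > 50 ug/mL, also a limit.
compound 3, `COc1cc2c(cc1OC)CN(S(=O)(=O)c1ccc(-n3cc(COc4ccc(C)cc4)nn3)cc1)CC2`, gives > 50 ug/mL, again a limit.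

Compound 3 therefore stands in this assay only at a limit, and the two other values shown sit at the same limit, as summarised by the limit of > 50 ug/mL in this assay, at which 3 of the 3 values shown sit. Compound 4, `COc1cc2c(cc1OC)CN(S(=O)(=O)c1ccc(-n3cc(COc4ccc(C=O)cc4OC)nn3)cc1)CC2`, differs from compound 3 by 4-formyl-2-methoxyphenyl in place of 4-methylphenyl on an oxygen on a saturated carbon. Within the data shown here, the only step measured between compounds that differ in one place runs from compound 1 to compound 2, a step that the two limits leave unreadable from compound 1 to compound 2, a formyl in place of a methyl on an aromatic carbon, and a formyl group likewise enters compound 4. Because a step that the two limits leave unreadable from compound 1 to compound 2 is unreadable between two limits, no direction or size can be taken from it, and no step beyond the scatter is expected for compound 4 in this assay, with the read-out most probably again a limit. The estimate for compound 4 is 60 ug/mL, within 30 ug/mL to 150 ug/mL. For compound 4 the expected step is a step that the limit leaves unreadable from compound 3 to compound 4.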

Compound 4, half-maximal inhibitory concentration: > 50 ug/mL
Compound 4 was reported as a limit (the forecaster's own chance of this, stated with the estimate: 85%); the middle value is on the limit's open side.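

Compound 3 and compound 4 both stand at a limit in this assay, so no step can be read between them. The compounds shown leave open what their actual half-maximal inhibitory concentrations are, as every value shown is a limit: the limit of > 50 ug/mL in this assay, at which 4 of the 4 values shown sit.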